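The source may hold more compounds than are shown below. What is called first, only, known or untested is meant among the compounds shown, and "the series" means these compounds.

Measured in a functional assay; on this read-out higher numbers stand for weaker inhibition and lower numbers for stronger inhibition:

- Compound 1 `CC(C)=CCOc1cc(O)c2c(c1)OC(c1ccccc1)CC2=O` gives 7320 nM
- Compound 2 `CC(C)=CCOc1cc(O)c2c(c1)OC(c1ccccc1F)CC2=O` gives 5300 nM
- Compound 3 `CC(C)=CCOc1cc(O)c2c(c1)OC(c1ccc(Cl)cc1Cl)CC2=O` gives 3340 nM

Compound 3, at 3340 nM, sits at the low end of this narrow range, but it is clearly separated only from compound 1. The data show a 2.2-fold lower number from compound 1 to compound 3 (0.34 log units; beyond the scatter), and also a 1.6-fold lower number from compound 2 to compound 3 (0.20 log units; within the scatter).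

Compound 4 `COc1ccc(C2CC(=O)c3c(O)cc(OCC=C(C)C)cc3O2)cc1` has 4-methoxyphenyl in place of 2,4-dichlorophenyl on a saturated ring carbon. Among the measured compounds shown here, no measured compound carries 4-methoxyphenyl, so the data offer no direct test of this change. The nearest evidence comes from changes to the same aromatic ring, and these were small: a 1.4-fold lower number from compound 1 to compound 2 (0.14 log units; within the scatter), and a 2.2-fold lower number from compound 1 to compound 3 (0.34 log units; beyond the scatter). Losing 2,4-dichlorophenyl may undo that modest gain, so a small move to a higher number is expected in this assay, towards compound 1 at 7320 nM. The expected change, which may not clear the scatter, is a 1.6-fold higher number from compound 3 to compound 4 (0.22 log units; within the scatter). For compound 4 the estimated value is 5500 nM, with an expected range from 2500 nM to 12000 nM.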

Compound 4, half-maximal inhibitory concentration: 5080 nM
For compound 4 the middle estimate is 1.1-fold (0.03 log units) above the measured one; measured number inside the range.
By their numbers in this assay, from the lowest: compounds 3, 4, 2 and 1 (each within the scatter of the next, the first and the last beyond it).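

Compound 4 adds a methoxy group, the only oxygen-bearing substituent on this aromatic ring among the compounds shown, yet in this assay it cannot be told apart from any earlier compound: a 1.4-fold lower number from compound 1 to compound 4 (0.16 log units; within the scatter), a 1.0-fold lower number from compound 2 to compound 4 (0.02 log units; within the scatter) and a 1.5-fold higher number from compound 3 to compound 4 (0.18 log units; within the scatter). Replacing 2,4-dichlorophenyl with 4-methoxyphenyl on this saturated ring carbon, next to the ring oxygen, therefore keeps the number within the scatter, and among all four compounds only compound 1 and compound 3 are clearly separated. No evidence is available to explain this result.

On these data alone, all four compounds keep a six-membered aromatic ring at this position, so it remains open whether a cyclohexyl group, or a phenyl ring bearing an amine or a carboxylic acid, would shift the number more. The shared core stays fixed throughout, leaving changes elsewhere in it untested here.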